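The source may hold more compounds than are shown below. What is called first, only, known or untested is meant among the compounds shown, and "the series" means these compounds.

Compound 1 `O=C(NO)c1ccc(NCc2nc(-c3ccc(Br)o3)nn2-c2ccccc2)cc1` was tested in an assay on Sf9 cells for inhibition of protein deacetylase HDAC6 (Homo sapiens), read by fluorescence, with a stated time of 40 min, tested at 100 nM (on this read-out higher numbers stand for more inhibition at the one concentration tested (going by the name of the read-out) and lower numbers for less inhibition), where compound 1 gives 55.8%. Going by the values given here, the only other measured compound, compound 2 `COc1ccc(-n2nc(-c3ccccc3)nc2CNc2ccc(C(=O)NO)cc2)cc1`, gives 63.4% in this assay; the two numbers lie within the usual scatter of each other, so neither can be set apart. Compound 3 `O=C(NO)c1ccc(NCc2nc(-c3ccc(Br)cc3)nn2-c2ccccc2)cc1` differs from compound 1 in one place: 4-bromophenyl in place of 5-bromofuran-2-yl on an aromatic carbon. Among the compounds with values here, no measured pair shows this change, so its effect is unknown here, and the step expected in this assay is a number 0.8 percentage points lower from compound 1 to compound 3 (within the scatter), nothing beyond the scatter. Compound 3 is therefore estimated at 55% in this assay, within 35% to 75%.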

Compound 3, a percentage reported as inhibition, at one concentration (the size of the read-out at that concentration, not a potency): 54.7%
Compound 3: middle estimate off by 0.3 percentage points, on the high side; low and high end bracket the measured number.
By their numbers in this assay, from the lowest: compounds 3, 1 and 2 (each within the scatter of the next).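

On the aromatic carbon of the five-membered aromatic ring with 3 nitrogen, 4-bromophenyl in place of 5-bromofuran-2-yl gives a number 1.1 percentage points lower from compound 1 to compound 3 (within the scatter) in this assay. This first reading of the change shows that, in this pair, the five-membered aromatic ring with 1 hetero atom and the six-membered aromatic ring of carbon only cannot be set apart at this position. Nothing measured bears on why the two behave alike.

The compounds shown leave open what a group of another kind on this carbon, such as an amine, a carboxylic acid or a longer chain, would do. They also leave open whether the bromine on either ring matters.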